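From 2,6-difluorophenyl to 2-methylphenyl on compound 1

The source may hold more compounds than are shown below. What is called first, only, known or untested is meant among the compounds shown, and "the series" means these compounds.

Measured values in a functional assay on MDA-MB-231 cells (Homo sapiens) for cytotoxicity, read by MTT assay, with a stated time of 72 h; a higher number here means a weaker inhibitor, a lower number a stronger inhibitor
compound 1 `O=C(CN1CCN(c2nnc(Cc3ccccc3)c3ccccc23)CC1)Nc1c(F)cccc1F` gives 5490 nM
compound 2 `O=C(CN1CCN(c2nnc(Cc3ccncc3)c3ccccc23)CC1)Nc1ccc(Br)cc1` gives 19 nM
compound 3 `O=C(CN1CCN(c2nnc(Cc3ccncc3)c3ccccc23)CC1)Nc1cccc(F)c1` gives 4.4 nM

Compound 1 has the highest number of the three, and compound 2 at 19 nM and compound 3 at 4.4 nM both lie far lower. Compound 4 `Cc1ccccc1NC(=O)CN1CCN(c2nnc(Cc3ccccc3)c3ccccc23)CC1` keeps the core of compound 1 but puts 2-methylphenyl in place of 2,6-difluorophenyl on an amide-type nitrogen. Among the measured compounds shown here, only one measured step involves a change at that place (a 4.3-fold lower number from compound 2 to compound 3 (0.64 log units; beyond the scatter)), and it is modest though beyond the scatter. It swaps a different pair of groups, and compounds 2 and 3 also differ from compound 1 elsewhere in their structure, so it gives only a rough size and no reliable direction. A similarly modest step in this assay is therefore expected, leaning slightly downward, and the estimated step is small (a 1.6-fold lower number from compound 1 to compound 4 (0.20 log units; within the scatter)). Compound 4 is expected at about 3500 nM with an estimated range from 700 nM to 15000 nM in this measurement.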

Compound 4, half-maximal inhibitory concentration: 17300 nM
The estimate for compound 4 lay 4.9-fold (0.69 log units) below the measured number, and the stated range ends below it.
By their numbers in this assay, from the lowest: compound 3; then compound 2; then compound 1; then compound 4.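

In this assay, 2-methylphenyl in place of 2,6-difluorophenyl on the amide-type nitrogen gives a 3.2-fold higher number from compound 1 to compound 4 (0.50 log units; beyond the scatter). Among the compounds shown here, this is the first step at this position measured on the core of compound 1, and it shows that the position still responds to a change of group there, with the size of the step beyond the scatter and its direction upward. The step is modest, so this one change does not shift the number by anything like the distance that separates these two compounds from compound 2 and compound 3. Nothing available explains why the number moves this way.

Still open, as far as these compounds go, is whether the same swap gives a step of similar size and direction on the core shared by compound 2 and compound 3. Also open, from the compounds shown here alone, is how a methoxy group or an amine would compare with the methyl group on this ring.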